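The source may report more compounds than this note shows. Statements on the series, on what has been measured and on what is new or still open speak of the compounds shown alone.

Measured compounds:
compound 1 `CCOc1ccccc1-c1ccc(-c2nc3cnccc3c(NC(COC)C(N)=O)c2C#N)cc1` gives 2.8 in a physicochemical assay for lipophilicity, read by HPLC, at pH 7.5; on this read-out higher numbers stand for higher lipophilicity and lower numbers for lower lipophilicity;
compound 2 `CCOc1ccccc1-c1ccc(-c2nc3cnccc3c(NC(C)C(=O)O)c2C#N)cc1` gives 2.1 in this assay;
compound 3 `CCOc1ccccc1-c1ccc(-c2nc3cnccc3c(N)c2C#N)cc1` gives 3 in this assay.

Compound 3 stands highest of the three numbers: compound 1 sits within the scatter of it, while compound 2 lies clearly lower. Compound 4 `CCOc1ccccc1-c1ccc(-c2nc3cnccc3c(N[C@H](CC)C(=O)N(C)C)c2C#N)cc1` has not yet been measured. It differs from compound 3 in one place: 1-(dimethylcarbamoyl)propyl in place of hydrogen on a nitrogen on an aromatic ring. Two measured steps change the same nitrogen. Removing a 1-carboxyethyl group gave a number 0.90 log units higher from compound 2 to compound 3 (beyond the scatter), and removing a 1-carbamoyl-2-methoxyethyl group gave a number 0.20 log units higher from compound 1 to compound 3 (within the scatter). The entering group resembles the carbamoyl case, with no donor and no acid, so a step within the scatter, slightly upward, is expected: a number 0.20 log units higher from compound 3 to compound 4 (within the scatter). Compound 4 is therefore estimated at 3.2, between 2.8 and 3.6.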

Compound 4, distribution coefficient: 3.7
For compound 4 the middle estimate is 0.50 log units below the measured one; the measured number lies above the stated range.
By their numbers in this assay, from the lowest: compound 2; then compounds 1 and 3 (each within the scatter of the next); then compound 4.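

On the nitrogen of the shared core, a substituent can lift the number in this assay clearly above that of the free amino compound: the step is a number 0.70 log units higher from compound 3 to compound 4 (beyond the scatter), whereas neither earlier substituent gave a number beyond the scatter above it. Swapping the earlier substituents for 1-(dimethylcarbamoyl)propyl gives a number 0.90 log units higher from compound 1 to compound 4 (beyond the scatter) and a number 1.60 log units higher from compound 2 to compound 4 (beyond the scatter), so this one position spans a wide range of numbers. No measurement shown gives a reason for these steps.

Still open, on these data alone, is which part of the entering group carries the rise, the ethyl branch or the two methyl groups on the amide nitrogen. A 1-(methylcarbamoyl)propyl group or a plain butyl chain on the same nitrogen would help to separate the two.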